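Replacing a Thiadiazole with Piperidine on the Shared Core

The source may hold more compounds than are shown below. What is called first, only, known or untested is meant among the compounds shown, and "the series" means these compounds.

Compound 1 `CCC(C)(C)Cc1c[nH]c(CCc2ccc(-c3cnccn3)cc2)n1` gives 431 nM in a functional assay on HEK293 cells for agonist activity at Bombesin receptor subtype-3 (Homo sapiens), read by luminescence and calcium flux, with a stated time of 10 min; a lower number here means that less compound is needed, a higher number that more compound is needed for the effect.
Compound 2 `CCC(C)(C)Cc1c[nH]c(CCc2ccc(-c3cccc(N)n3)cc2)n1` gives 37 nM in this assay.
Compound 3 `CCC(C)(C)Cc1c[nH]c(CCc2ccc(-c3csnn3)cc2)n1` gives 538 nM in this assay.

Compound 3 carries the highest of the three numbers, though its gap to compound 1 is small: a 1.2-fold higher number from compound 1 to compound 3 (0.10 log units; within the scatter) lies within the scatter. Compound 2 stands furthest from it, since a 15-fold higher number from compound 2 to compound 3 (1.16 log units; beyond the scatter) is a large step. Compound 4 `CCC(C)(C)Cc1c[nH]c(CCc2ccc(N3CCCCC3)cc2)n1` has not yet been measured. Its difference from compound 3 is piperidin-1-yl in place of 1,2,3-thiadiazol-4-yl on an aromatic carbon. Two measured steps involve the group that leaves: a 1.2-fold higher number from compound 1 to compound 3 (0.10 log units; within the scatter) was small, and a 15-fold higher number from compound 2 to compound 3 (1.16 log units; beyond the scatter) was large. Going by the values given here, no measured compound carries a piperidin-1-yl, or any non-aromatic ring, at this position, so the entering group has no direct precedent. Among the compounds with values here, the only exchange among the three that moved the number strongly, a 12-fold lower number from compound 1 to compound 2 (1.07 log units; beyond the scatter), involved the 6-aminopyridin-2-yl, which plays no part here. Compound 4 is therefore expected to remain close to compound 3, with the estimated step being a 1.2-fold lower number from compound 3 to compound 4 (0.08 log units; within the scatter). For compound 4 the expected value in this assay is 450 nM, with a range from 120 nM to 1700 nM.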

Compound 4, half-maximal effective concentration: 171 nM
Estimate against measurement, compound 4: 2.6-fold (0.42 log units) above, and the stated range covers the measured number.
By their numbers in this assay, from the lowest: compound 2; then compound 4; then compounds 1 and 3 (each within the scatter of the next).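

At this position on the shared core, a non-aromatic ring does better than two of the aromatic rings in this assay: the piperidin-1-yl gives a 3.1-fold lower number from compound 3 to compound 4 (0.50 log units; beyond the scatter) and a 2.5-fold lower number from compound 1 to compound 4 (0.40 log units; beyond the scatter). An aromatic ring is therefore not needed here for the number to fall. The 6-aminopyridin-2-yl still holds the lowest number, with a 4.6-fold higher number from compound 2 to compound 4 (0.66 log units; beyond the scatter) as a modest step, so the piperidin-1-yl comes only part of the way towards compound 2.

As far as these compounds go, whether a morpholine, a pyrrolidine or an open-chain diethylamino group on this aromatic carbon would behave like the piperidin-1-yl remains open, as does the effect of an amino group added to the piperidine ring. Nothing available explains why these exchanges move the number as they do.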